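Trading fluoro for chloro in a permeability series

This account rests on a few compounds, and the source may have more. Where it says the series, first, only, none or still open, it means among the compounds named here.

In an ADME assay for permeability, using PAMPA, at pH 7.4 (on this read-out higher numbers stand for higher permeability and lower numbers for lower permeability), compound 1 `Cc1[nH]c2cccc(Cl)c2c(=O)c1Cc1ccccc1` gives 251 10^-6 cm/s and compound 2 `COc1ccc2nc(C)c(Cc3ccccc3)c(OC)c2c1` gives 1070 10^-6 cm/s as its reading. Compound 3 `CCc1c(C)[nH]c2cc(OC)c(F)cc2c1=O` stands lowest of the three at 19.1 10^-6 cm/s with both other numbers higher by more than the usual scatter. Compound 4 `CCc1c(C)[nH]c2cc(OC)c(Cl)cc2c1=O` has not been measured yet. It differs from compound 3 by one swap, chloro in place of fluoro on an aromatic carbon which means chloro in place of fluoro on an aromatic carbon, ortho to a methoxy group. Among the measured compounds shown here, no two measured compounds differ in only one place, so the data offer no direct precedent for this swap. Compound 1 also carries a chloro group and reads 251 10^-6 cm/s on this scale, but it differs from compound 3 in more than one place, which makes it weak support. In this assay a small rise is expected, a 1.8-fold higher number from compound 3 to compound 4 (0.26 log units; within the scatter) as the estimated step, and it may stay within the scatter. Compound 4 is estimated at 35 10^-6 cm/s with an expected range of 14 10^-6 cm/s to 90 10^-6 cm/s for its reading.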

Compound 4, apparent permeability: 57.3 10^-6 cm/s
The estimate for compound 4 lay 1.6-fold (0.21 log units) below the measured number; low and high end bracket the measured number.
By their numbers in this assay, from the lowest: compound 3; then compound 4; then compound 1; then compound 2.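

Among the compounds shown here, this is the first comparison in the set that changes one place only: with the rest of the molecule kept, chloro in place of fluoro on this aromatic carbon, ortho to a methoxy group, gives a 3.0-fold higher number from compound 3 to compound 4 (0.48 log units; beyond the scatter) in this assay. The step is modest but lies beyond the usual scatter of repeated measurements, so the reading at this position does depend on which of these two halogens it carries. Nothing measured here accounts for the size or direction of the step, so it stands as an observation only. A single pair cannot tell whether the same swap would move the reading the same way on a different core. Also open, going by these compounds, is what another group on this carbon, such as a nitrile, a trifluoromethyl or an amine, would give.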